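The source may report more compounds than this note shows. Statements on the series, on what has been measured and on what is new or still open speak of the compounds shown alone.

In a functional assay on HFF cells (Homo sapiens) for cytotoxicity (a lower number here means a stronger inhibitor, a higher number a weaker inhibitor), compound 1 (`CSCC1OC(n2c(Cl)nc3cc(Cl)c(Cl)cc32)C(OC(C)=O)C1OC(C)=O`) gives 32000 nM and compound 2 (`COC[C@H]1OC(n2c(Cl)nc3cc(Cl)c(Cl)cc32)[C@H](O)[C@@H]1O`) gives 32000 nM, so compound 2 stands level with compound 1. Compound 3 (`O[C@@H]1[C@@H](CF)OC(n2c(Cl)nc3cc(Cl)c(Cl)cc32)[C@@H]1O`) carries fluoro in place of methoxy on a saturated chain carbon bound to a saturated ring carbon. For the measured compounds named here, no measured single-place step is available to size this change, so the only guide is compound 2 at 32000 nM. No shift beyond the scatter in this assay is expected in either direction, the expected step being no change at the digits printed from compound 2 to compound 3 (within the scatter). For compound 3 the estimated value is 32000 nM, with an expected range of 10000 nM to 100000 nM.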

Compound 3, half-maximal inhibitory concentration: 32000 nM
For compound 3 middle estimate and measured number coincide at the digits printed; measured number inside the range.
By their numbers in this assay, from the lowest: compounds 1, 2 and 3 (each within the scatter of the next).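

Fluoro in place of methoxy on a saturated chain carbon bound to a saturated ring carbon now has a measured size in this assay with no change at the digits printed from compound 2 to compound 3 (within the scatter) as its step. At this place, methoxymethyl to fluoromethyl therefore leaves the read-out level, although the group entering is smaller by one heavy atom. Nothing at hand accounts for this result.

Going by these compounds, whether an amine, a carboxylic acid or a longer chain at this place would shift the value beyond the scatter remains open.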